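Tert-butyl replaces 3-hydroxyphenyl on the triple bond

A few compounds are considered here, and "the series" means these few. Any claim that something is new, unique, unknown or untested is made for them only; others in the source may bear on it.

Compound 1 `Cn1cncc1C(OCc1ccc(C#N)cc1C#Cc1ccc(C#N)cc1)c1ccc(C#N)cc1` gives 11.6 nM in a functional assay on NIH3T3 cells (Mus musculus); a lower number here means that less compound is needed, a higher number that more compound is needed for the effect
Compound 2 `Cn1cncc1C(OCc1ccc(C#N)cc1C#Cc1cccc(O)c1)c1ccc(C#N)cc1` gives > 0.1 nM in this assay as a limit

Compound 2 stands at > 0.1 nM, which is a limit of the assay and not a number. Compound 3 `Cn1cncc1C(OCc1ccc(C#N)cc1C#CC(C)(C)C)c1ccc(C#N)cc1` differs from it by tert-butyl in place of 3-hydroxyphenyl on a triple-bonded carbon. For the measured compounds named here, the one measured step that bears on this, a step that the limit leaves unreadable from compound 1 to compound 2, changes the group on the same carbon, but its size cannot be read. It gives no firm size or direction for this assay. Going by the values given here, the only number is that of compound 1 at 11.6 nM, so the expectation stays close to it. An estimated step that the limit leaves unreadable from compound 2 to compound 3 is expected, with its direction open. Compound 3 is expected near 20 nM (estimated range 3 nM to 150 nM).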

Compound 3, half-maximal effective concentration: 76.9 nM
The estimate for compound 3 lay 3.8-fold (0.58 log units) below the measured number; the measured number falls inside the stated range.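

For the compounds shown here, with tert-butyl in place of 4-cyanophenyl on the triple-bonded carbon, this assay shows a 6.6-fold higher number from compound 1 to compound 3 (0.82 log units; beyond the scatter), the first readable step at this position. The group on this carbon can therefore lack a ring and still give a measured number, though a higher one. The steps involving compound 2 cannot be read, as compound 2 stands at a limit of the assay and not a number: the limit of > 0.1 nM in this assay, at which 1 of the 3 values shown sits.

Going by these compounds, what remains open is whether the nitrile or the ring of 4-cyanophenyl accounts for the step. On these data alone, how an unsubstituted phenyl, an amine or a carboxylic acid would read on this carbon also stays open.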